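Hydroxy in place of the chain on the amine nitrogen

The source may hold more compounds than are shown below. What is called first, only, known or untested is meant among the compounds shown, and "the series" means these compounds.

In an ADME assay on Vero cells (Chlorocebus sabaeus) for cytotoxicity, read by MTT assay, with a stated time of 72 h (on this read-out lower numbers stand for higher toxicity in this test and higher numbers for lower toxicity in this test), compound 3 (`COc1c(N2CCN(C/C(C)=N/O)C(C)C2)c(F)cc2c(=O)c(C(=O)O)cn(C3CC3)c12`) gives 177 ug/mL, the lowest of the three numbers, although it does not separate from compound 1 (`COc1c(N2CCN(CC#N)C(C)C2)c(F)cc2c(=O)c(C(=O)O)cn(C3CC3)c12`) at 354 ug/mL: a 2.0-fold lower number from compound 1 to compound 3 (0.30 log units; within the scatter). Compound 2 (`COc1c(N2CCN(C/C(C)=N/NC(C)=O)C(C)C2)c(F)cc2c(=O)c(C(=O)O)cn(C3CC3)c12`) stands apart at 707 ug/mL: a 4.0-fold lower number from compound 2 to compound 3 (0.60 log units; beyond the scatter). The remaining pair shows a 2.0-fold higher number from compound 1 to compound 2 (0.30 log units; within the scatter).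

Compound 4 (`COc1c(N2CCN(O)C(C)C2)c(F)cc2c(=O)c(C(=O)O)cn(C3CC3)c12`) carries hydroxy on an amine nitrogen in a ring: one oxygen atom in place of a group of 5 heavy atoms (3 carbon, 1 nitrogen, 1 oxygen; no ring), on an amine nitrogen in a ring. All three measured steps alter the group on a saturated chain carbon bound to an amine nitrogen in a ring, and none removes the chain. They therefore bear on this change only indirectly. Going by the values given here, only the step between compound 2 and compound 3 exceeds the scatter, and it is modest, so a large move seems unlikely. The expected step is small and within the scatter, slightly upward: a 1.4-fold higher number from compound 3 to compound 4 (0.15 log units; within the scatter). The direction remains uncertain. For compound 4 the estimated value is 250 ug/mL, with an expected range of 100 ug/mL to 650 ug/mL.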

Compound 4, half-maximal cytotoxic concentration: 19.7 ug/mL
Compound 4: middle estimate off by 13-fold (1.10 log units), on the high side; measured number outside the range, below it.
By their numbers in this assay, from the lowest: compound 4; then compounds 3, 1 and 2 (each within the scatter of the next, the first and the last beyond it).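

In this assay, hydroxy on the amine nitrogen in the ring gives a result that none of the chain variations showed: a 9.0-fold lower number from compound 3 to compound 4 (0.95 log units; beyond the scatter), an 18-fold lower number from compound 1 to compound 4 (1.25 log units; beyond the scatter) and a 36-fold lower number from compound 2 to compound 4 (1.55 log units; beyond the scatter). Among compounds 1, 2 and 3 only the group carried on the saturated chain carbon changes, and the one step beyond the scatter there is modest, so in these four compounds the larger shift, toward higher toxicity in this test, comes with hydroxy directly on the ring nitrogen in place of the chain. No measurement at hand accounts for this shift.

On these data alone, it remains open whether the low number belongs to the hydroxy itself or to the loss of the chain, a question that methoxy or ethyl on this amine nitrogen would address. Also open, as far as these compounds go, is how a chain ending in a carboxylic acid or an amine would stand against compound 1 and compound 4.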